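The compounds below may be only part of what the source reports. "The series", "measured", "known", "first", "only" and "open" are said of these compounds alone.

The measured compounds in this set are:

compound 1 `CN1CCN(c2ccc(Nc3ncc4c(n3)N(C3CCCC3)CC(=O)N4C)cc2)CC1`, 3290 nM
compound 2 `CN1C(=O)CN(C2CCCC2)c2nc(Nc3ccc(N4CCCCC4)cc3)ncc21`, 6100 nM
compound 3 `CN1CCN(c2ccc(Nc3ncc4c(n3)N(C3CCCC3)CC(=O)N4C)nc2)CC1`, 9730 nM

All three were tested in a functional assay on HCT-116 cells (Homo sapiens) for inhibition, read by MTT assay, with a stated time of 48 h; a lower number here means a stronger inhibitor, a higher number a weaker inhibitor. Compound 1 gives 3290 nM, compound 2 gives 6100 nM and compound 3 gives 9730 nM in this assay. Compound 2 is related to compound 1 by a single change, (piperidin-1-yl in place of 4-methylpiperazin-1-yl on an aromatic carbon), and that change made a step of a 1.9-fold higher number from compound 1 to compound 2 (0.27 log units; within the scatter). The two values of compound 2 and compound 3 lie close to each other and show no ordering; compound 3 and compound 1, by contrast, are separated by a gap that goes beyond the usual scatter.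

The unmeasured compound 4 `CN1C(=O)CN(C2CCCC2)c2nc(Nc3ccc(N4CCCCC4)cn3)ncc21` is related to compound 3 by the same kind of change, (piperidin-1-yl in place of 4-methylpiperazin-1-yl on an aromatic carbon). The difference between the core of compound 3 and the core of compound 1 is not broken down here. What differs around the place of the change is that in compound 1 the group sits on a six-membered aromatic ring of carbon only, whereas in compound 3 it sits on a six-membered aromatic ring with 1 nitrogen, two atoms from the ring nitrogen, so this is the same kind of change, not the same.

For compound 4 in this assay the expected step is a 1.8-fold higher number from compound 3 to compound 4 (0.27 log units; within the scatter), set beside the measured step of a 1.9-fold higher number from compound 1 to compound 2 (0.27 log units; within the scatter), because compound 2 stands at 6100 nM after the same kind of change from compound 1. The estimate for compound 4 is 18000 nM, with an expected range from 8000 nM to 45000 nM.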

Compound 4, half-maximal inhibitory concentration: 3890 nM
Beside the measured number, compound 4's estimate is 4.6-fold (0.67 log units) above it, and the stated range ends above it.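

In this assay, piperidin-1-yl in place of 4-methylpiperazin-1-yl gave a 2.5-fold lower number from compound 3 to compound 4 (0.40 log units; beyond the scatter), and this step does not match the one measured for the same kind of change on the other core: the same change on two cores in this assay, a 1.9-fold higher number (0.27 log units; within the scatter) from compound 1 to compound 2 and a 2.5-fold lower number (0.40 log units; beyond the scatter) from compound 3 to compound 4, 4.6-fold (0.67 log units) apart, beyond the scatter of two such steps. Within these compounds, then, the step measured on the core of compound 1 was not a reliable guide to the step on the core of compound 3, where the group sits on a six-membered aromatic ring with 1 nitrogen, two atoms from the ring nitrogen, rather than on a ring of carbon only. Within the data shown here, this does not show that the change has a reversed effect in general or why the two steps differ, since each core supplies only one pair, the step on the core of compound 1 lies within the scatter, and the ring nitrogen cannot be separated from any other difference between the cores.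

The compounds shown leave open how morpholin-4-yl or an open-chain dimethylamino group would behave at this place on each core. They also leave open whether a third core carrying the same pair of groups would follow either step in this assay.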